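The source may hold more compounds than are shown below. What is called first, only, known or untested is meant among the compounds shown, and "the series" means these compounds.

Measured compounds in a functional assay on CHO-K1 cells for antagonist activity at transient receptor potential cation channel subfamily V member 1 (Homo sapiens), read by FLIPR; a lower number here means a stronger inhibitor, a higher number a weaker inhibitor:
- compound 1 `CCCCNc1nc(C(F)(F)F)ccc1CNC(=O)C(C)c1ccc(NS(C)(=O)=O)c(F)c1`: 9.1 nM
- compound 2 `CC(C(=O)NCc1ccc(C(F)(F)F)nc1NC1CCCCC1)c1ccc(NS(C)(=O)=O)c(F)c1`: 20.4 nM
- compound 3 `CC(C(=O)NCc1ccc(C(F)(F)F)nc1N1CCCCC1C)c1ccc(NS(C)(=O)=O)c(F)c1`: 2.9 nM

Compound 3 stands lowest of the three in this assay: a 3.1-fold lower number from compound 1 to compound 3 (0.50 log units; beyond the scatter) and a 7.0-fold lower number from compound 2 to compound 3 (0.85 log units; beyond the scatter), both beyond the scatter. Compound 4 `CC(C(=O)NCc1ccc(C(F)(F)F)nc1N1CCC(=O)CC1)c1ccc(NS(C)(=O)=O)c(F)c1` is not yet measured. Its change from compound 3 is 4-oxopiperidin-1-yl in place of 2-methylpiperidin-1-yl on an aromatic carbon.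

Among the compounds with values here, two measured steps bear on this position: a 3.1-fold lower number from compound 1 to compound 3 (0.50 log units; beyond the scatter) and a 7.0-fold lower number from compound 2 to compound 3 (0.85 log units; beyond the scatter) show that the 2-methylpiperidin-1-yl ring gives the lowest number of the series. Within the data shown here, no measured step covers a carbonyl in that ring or loss of the methyl, so the direction of the new change is uncertain. A modest rise back toward the level of compound 1 is expected, a 5.2-fold higher number from compound 3 to compound 4 (0.71 log units; beyond the scatter). Compound 4 is estimated at 15 nM, range 4 nM to 60 nM.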

Compound 4, inhibition constant: 91 nM
Compound 4: middle estimate off by 6.1-fold (0.78 log units), on the low side; measured number above the stated range.
By their numbers in this assay, from the lowest: compound 3; then compound 1; then compound 2; then compound 4.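

In this assay, 4-oxopiperidin-1-yl in place of 2-methylpiperidin-1-yl is the largest step in the series (a 31-fold higher number from compound 3 to compound 4 (1.50 log units; beyond the scatter)), so this position does not treat all six-membered rings bound through nitrogen alike. Compound 4 also stands above the compounds carrying butylamino (a 10-fold higher number from compound 1 to compound 4 (1.00 log units; beyond the scatter)) and cyclohexylamino (a 4.5-fold higher number from compound 2 to compound 4 (0.65 log units; beyond the scatter)), so attachment through a ring nitrogen does not by itself give a low number. Nothing available explains this rise.

From the compounds shown here alone, the carbonyl and the loss of the methyl arrive together, so their separate contributions remain open. Unsubstituted piperidin-1-yl or 4-hydroxypiperidin-1-yl would separate them.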